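Working notes: from compound 3 to compound 4

A few compounds are considered here, and "the series" means these few. Any claim that something is new, unique, unknown or untested is made for them only; others in the source may bear on it.

Measured in a functional assay on HeLa cells (Homo sapiens) for antiproliferative activity, with a stated time of 24 h; on this read-out lower numbers stand for stronger inhibition and higher numbers for weaker inhibition:
compound 1 `NC(=O)c1c(NC(=O)c2ccccc2F)sc2c1CCN(Cc1cccc(Cl)c1)C2`: 49500 nM
compound 2 `NC(=O)c1c(NC(=O)c2ccccc2F)sc2c1CCN(Cc1c(Cl)cccc1Cl)C2`: 33000 nM
compound 3 `NC(=O)c1c(NC(=O)c2ccccc2F)sc2c1CCN(C(=S)Nc1ccccc1Cl)C2`: 19400 nM

Compound 3 stands lowest of the three numbers; its gap to compound 2 is within the scatter, and only its gap to compound 1 is beyond it. All three measured steps, a 2.6-fold lower number from compound 1 to compound 3 (0.41 log units; beyond the scatter), a 1.5-fold lower number from compound 1 to compound 2 (0.18 log units; within the scatter) and a 1.7-fold lower number from compound 2 to compound 3 (0.23 log units; within the scatter), concern the group on the amine nitrogen in the ring.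

Compound 4 `CSc1ccccc1C(=O)Nc1sc2c(c1C(N)=O)CCN(C(=S)Nc1ccccc1Cl)C2` differs from compound 3 by methylsulfanyl in place of fluoro on an aromatic carbon. Within the data shown here, none of the measured steps touches that aromatic carbon, so no measured step bears on this change. Compound 4 is therefore expected to show a step of a 1.0-fold lower number from compound 3 to compound 4 (0.01 log units; within the scatter), nothing beyond the scatter. Compound 4 is estimated at 19000 nM, with a range of 7000 nM to 55000 nM.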

Compound 4, half-maximal inhibitory concentration: 34700 nM
For compound 4 the middle estimate is 1.8-fold (0.26 log units) below the measured one; low and high end bracket the measured number.
By their numbers in this assay, from the lowest: compounds 3, 2, 4 and 1 (each within the scatter of the next, the first and the last beyond it).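

The aromatic carbon ortho to a large group now has a measured step: in this assay methylsulfanyl in place of fluoro gives a 1.8-fold higher number from compound 3 to compound 4 (0.25 log units; within the scatter) and so no change that can be told from the scatter. Among these compounds, this position therefore accepts this exchange on the read-out, whereas the earlier steps concerned only the amine nitrogen in the ring. No measured evidence bears on this result. Still open, from the compounds shown here alone, is how an amine, a hydroxyl or a carboxylic acid would read on this carbon. Also open, going by these compounds, is whether methylsulfanyl reads alike with other groups on that nitrogen.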